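This account rests on a few compounds, and the source may have more. Where it says the series, first, only, none or still open, it means among the compounds named here.

Values in a functional assay on KB cells (Homo sapiens) for inhibition, read by MTT assay, with a stated time of 24 h, tested at 10 ug/mL; a higher number here means more inhibition of growth at the concentration tested, a lower number less inhibition of growth:
- compound 1 `CC(=O)SCCC(CCCCC(=O)O)SC(C)=O` gives 8.88%
- compound 2 `O=C(CCCCC1CCSS1)NO` gives 0.89%
- compound 3 `O=C(CCCCC1CCSS1)Nc1ccc(Br)cn1` gives 35.1%

In this assay compound 1 lies within the usual scatter of compound 2 and falls well short of compound 3, a gap beyond the scatter. The next compound to be read is compound 4 `CC(=O)SCCC(CCCCC(=O)Nc1ccccc1)SC(C)=O`, which differs from compound 1 as follows: anilino in place of hydroxy on a carbonyl carbon.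

Going by the values given here, no measured pair isolates this change, so the data give no direct size for it. Compounds 1 and 3 differ in more than one place, which makes the comparison only a loose guide. Even so, compound 3 (35.1%) is the one measured compound with an aromatic ring on its amide nitrogen, and it gives the only clearly higher reading. A rise in this assay is therefore expected, probably beyond the scatter, although a smaller move remains possible. The expected step is a number 15.1 percentage points higher from compound 1 to compound 4 (beyond the scatter) in the direction of more inhibition. For compound 4 the estimated value is 24% with an expected range from 8% to 48% as its limits.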

Compound 4, percent growth inhibition at one concentration: 2.5%
Compound 4: middle estimate off by 21.5 percentage points, on the high side; measured number outside the range, below it.
By their numbers in this assay, from the lowest: compounds 2, 4 and 1 (each within the scatter of the next); then compound 3.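

In this assay, anilino in place of hydroxy on a carbonyl carbon gives a number 6.4 percentage points lower from compound 1 to compound 4 (within the scatter), so this step does not separate compound 4 from compound 1. The position thus accepts an aromatic ring of carbon only, carried through the amide nitrogen, with no readable change in growth inhibition, and on the core of compound 1 that ring alone does not lift the reading out of the scatter. No measurement bears on why the reading stays there.

Still open, from the compounds shown here alone, is whether a bromoanilino group, a benzylamino group or a methyl ester on the same carbonyl carbon would read differently on this core. Going by these compounds, it is also open whether anilino would behave the same way on a core that keeps the ring with its two sulfur atoms.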